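The source may report more compounds than this note shows. Statements on the series, on what has been measured and on what is new or still open speak of the compounds shown alone.

Of the compounds shown here, three built on one shared core have been tested in an ADME assay on cells (Mus musculus, strain BALB/c) for cytotoxicity, read by MTT assay, with a stated time of 24 h; a higher number here means that more compound is tolerated, a lower number that less compound is tolerated. Compound 1 `COc1cc(-c2nnc(SCc3cccc(Br)c3)o2)ccc1O` gives 382000 nM. Compound 2 `COc1cc(-c2nnc(SCc3cccc([N+](=O)[O-])c3)o2)ccc1O` gives 392000 nM, and compound 3 `COc1cccc(CSc2nnc(-c3ccc(O)c(OC)c3)o2)c1` gives 389000 nM. All three numbers lie within the scatter of one another: the step of a 1.0-fold higher number from compound 1 to compound 2 (0.01 log units; within the scatter), the step of a 1.0-fold higher number from compound 1 to compound 3 (0.01 log units; within the scatter) and the step of a 1.0-fold lower number from compound 2 to compound 3 (0.00 log units; within the scatter) each show no change beyond what repeated measurements would give. Compound 1 therefore stands on the same footing as the other two, its number being indistinguishable from either.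

Compound 4 `COc1cc(-c2nnc(SCc3cccc(Br)c3)o2)ccc1OCc1cccc(Br)c1` has not yet been measured in this assay. It differs from compound 1 by one change: 3-bromobenzyl in place of hydrogen on an oxygen on an aromatic ring. None of the three measured steps touches this position; each of them swaps one group for another on the benzyl ring, and each left the number where it was. Within the data shown here, there is thus no measured step that speaks directly to capping the hydroxy with a 3-bromobenzyl group, only the observation that the series has so far been flat.

On that basis compound 4 is expected to give about 330000 nM, somewhere between 140000 nM and 750000 nM, which would mean a step of a 1.2-fold lower number from compound 1 to compound 4 (0.06 log units; within the scatter) that stays within the scatter.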

Compound 4, half-maximal cytotoxic concentration: 161000 nM
Compound 4: the middle estimate sits 2.0-fold (0.31 log units) above what was measured; low and high end bracket the measured number.
By their numbers in this assay, from the lowest: compound 4; then compounds 1, 3 and 2 (each within the scatter of the next).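

Replacing the hydrogen on this oxygen with 3-bromobenzyl is the only change shown that moves the number in this assay, giving a 2.4-fold lower number from compound 1 to compound 4 (0.38 log units; beyond the scatter), a modest step but one that lies beyond the scatter. The swaps on the benzyl ring that link compounds 1, 2 and 3 all stayed within the scatter, so among these compounds the hydroxy is the one place where a change registers, and capping it goes with less compound being tolerated. No measurement at hand offers an explanation for this step.

On these data alone, with a single capped compound, it remains open whether the step follows from losing the hydroxy hydrogen or from adding this particular group, a question that a small methyl ether, an unsubstituted benzyl, or a chain ending in an amine or a carboxylic acid on the same oxygen could help settle. As far as these compounds go, it also remains open whether the 3-bromobenzyl cap would give a similar step on compound 2 or compound 3, which carry nitro and methoxy on the benzyl ring in place of bromo.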